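The source may report more compounds than this note shows. Statements on the series, on what has been measured and on what is new or still open speak of the compounds shown alone.

Compound 1 `CC1(C)CNC(=O)c2cc(-c3ccc([N+](=O)[O-])cc3)n(-c3ccc(Cl)cc3)c2C1`: 20000 nM
Compound 2 `CC1(C)CNC(=O)c2cc3n(c2C1)CCc1ccccc1-3`: > 100000 nM

In a functional assay on HCT-15 cells (Homo sapiens) for cytotoxicity, read by sulforhodamine B assay, with a stated time of 48 h (on this read-out higher numbers stand for weaker inhibition and lower numbers for stronger inhibition), compound 1 gives 20000 nM, which is a measured number. Compound 2 reads > 100000 nM, and this is a limit of the assay, not a number. Compound 2 therefore has no exact place on the scale and stands at the limit of > 100000 nM in this assay, at which 1 of the 2 values shown sits.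

Compound 3 `CC1(C)CNC(=O)c2cc3n(c2C1)CCc1cc(Cl)ccc1-3` is compound 2 with a single change: chloro in place of hydrogen on an aromatic carbon. Among the measured compounds shown here, no two measured compounds here differ in just one place, so no measured step shows what such a change does, and any expectation must stay loose. A small gain in strength is expected, meaning a somewhat lower number in this assay, though compound 3 may well remain at the limit too. The expected size of this change, counted from a limit and so only a rough estimate, is an at least 1.6-fold lower number from compound 2 to compound 3 (0.22 log units; that floor lies within the scatter). Compound 3 is expected to read about 60000 nM, with an estimated range of 20000 nM to 100000 nM.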

Compound 3, half-maximal inhibitory concentration: 39700 nM
Beside the measured number, compound 3's estimate is 1.5-fold (0.18 log units) above it; low and high end bracket the measured number.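

The value of compound 2 is a limit and not a number: the limit of > 100000 nM in this assay, at which 1 of the 3 values shown sits. In this assay, chloro in place of hydrogen on an aromatic carbon, meta to a fused ring and para to a fused ring, gives an at least 2.5-fold lower number from compound 2 to compound 3 (0.40 log units; beyond the scatter), so a single added chlorine at this position is enough to bring compound 3 onto the measurable scale, at 39700 nM. Among the compounds shown here, this is the first step that can be read at all, and it is a floor: the true gap could be larger, and the data cannot tell how much larger.

One pair of compounds cannot show whether the gain belongs to chloro itself or to any group placed at this position, so a fluoro, a methyl, a methoxy or an amine there remains an open comparison, as does chloro on the other aromatic carbons of this ring. Compound 1 also carries a chloro group, but it differs from compound 2 and compound 3 in more than one place, so it says nothing about this step.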